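A few compounds are considered here, and "the series" means these few. Any claim that something is new, unique, unknown or untested is made for them only; others in the source may bear on it.

Compound 1 `CC1CCN(C2CCN(S(=O)(=O)c3ccc(-c4ccccc4F)cc3)CC2)CC1`, compound 2 `CC1CCN(C2CCN(S(=O)(=O)c3ccc(OCc4ccccc4)cc3)CC2)CC1` and compound 3 `CC1CCN(C2CCN(S(=O)(=O)c3ccc(OC(F)(F)F)cc3)CC2)CC1` share one core and differ in a single group. All three were tested in an ADME assay on HCT-116 cells (Homo sapiens) for cytotoxicity, read by CellTiter-Glo, with a stated time of 72 h; a lower number here means a stronger inhibitor, a higher number a weaker inhibitor. Compound 1 gives > 5000 nM, which is a limit and not a number. Compound 2 gives > 5000 nM, which is also a limit. Compound 3, the starting point here, gives > 5000 nM, again only a limit.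

Compound 4 `CCCCOc1ccc(S(=O)(=O)N2CCC(N3CCC(C)CC3)CC2)cc1` has not yet been measured. Its difference from compound 3 is butyl in place of trifluoromethyl on an oxygen on an aromatic ring. In other words, trifluoromethoxy becomes butoxy.

The closest measured change, made on that same oxygen, is a step that the two limits leave unreadable from compound 2 to compound 3. The two other measured changes are a step that the two limits leave unreadable from compound 1 to compound 2 and a step that the two limits leave unreadable from compound 1 to compound 3. None of these three steps has a readable size, so they give no direction for the new change. What they do show is a shared result, (the limit of > 5000 nM in this assay, at which 3 of the 3 values shown sit), with no exception among the three compounds. On that basis, the expected change, a step that the limit leaves unreadable from compound 3 to compound 4, is no clear move in either direction, and the assay will probably report only a limit again. For compound 4 the estimated value is 7000 nM, with an expected range from 3000 nM to 20000 nM.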

Compound 4, half-maximal inhibitory concentration: > 5000 nM
Compound 4 gave a limit, no number; the forecaster's own chance of this, stated with the estimate: 85%; the middle value does not contradict the limit.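

In this assay compound 4 gives > 5000 nM, which is again only a limit and not a number. Its steps to compound 1, compound 2 and compound 3 therefore cannot be read. All four compounds share one result: the limit of > 5000 nM in this assay, at which 4 of the 4 values shown sit.

The compounds shown leave open whether these groups differ at all in strength, and which group, if any, would give a readable number.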